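The compounds below may be only part of what the source reports. "The series", "measured", "known", "first", "only" and "open" are said of these compounds alone.

Measured compounds:
compound 1, `COc1cc(N/C=C\C(=O)c2cn(-c3ccccc3)nc2-c2ccccc2)cc(OC)c1OC`, 6340 nM
compound 2, `COc1ccc(N/C=C\C(=O)c2cn(-c3ccccc3)nc2-c2ccc(OC)cc2)cc1`, 6780 nM

In a functional assay on A549 cells (Homo sapiens) for antiproliferative activity, read by MTT assay, with a stated time of 48 h (a lower number here means a stronger inhibitor, a higher number a weaker inhibitor), compound 2 gives 6780 nM, the higher of the two numbers; its nearest neighbour, compound 1, gives 6340 nM, and the two values lie within the scatter of each other, so no order between them can be read. Compound 3, `COc1ccc(-c2nn(-c3ccccc3)cc2C(=O)/C=C\Nc2cc(OC)c(OC)c(OC)c2)cc1`, has not been measured. It differs from compound 2 in one place: 3,4,5-trimethoxyphenyl in place of 4-methoxyphenyl on an amine nitrogen. Among the compounds with values here, no step between measured compounds that differ in a single place is available, so the effect of this change cannot be taken from a measured pair. What the data do show is that compound 1, which carries the 3,4,5-trimethoxyphenyl on the amine nitrogen, and compound 2, which carries 4-methoxyphenyl there, give values within the scatter of one another. On that basis the step of a 1.1-fold lower number from compound 2 to compound 3 (0.05 log units; within the scatter) is expected to be small, with no direction that reaches beyond the scatter. Compound 3 is therefore expected to give about 6000 nM in this assay, within a range from 2500 nM to 14000 nM.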

Compound 3, half-maximal inhibitory concentration: 11200 nM
Estimate against measurement, compound 3: 1.9-fold (0.27 log units) below; the range from low to high includes it.
By their numbers in this assay, from the lowest: compounds 1, 2 and 3 (each within the scatter of the next).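

In this assay, the exchange of 4-methoxyphenyl for 3,4,5-trimethoxyphenyl on an amine nitrogen can now be read from a measured pair, and the step of a 1.7-fold higher number from compound 2 to compound 3 (0.22 log units; within the scatter) gives no order between the two groups at this position. A second pair, with 3,4,5-trimethoxyphenyl on the amine nitrogen in both compounds, puts methoxy in place of hydrogen on an aromatic carbon, and its step of a 1.8-fold higher number from compound 1 to compound 3 (0.25 log units; within the scatter) likewise cannot be told from the scatter, so neither single change yet separates the compounds in this assay. No measurement beyond these antiproliferative numbers is available to account for either step.

Every group shown on the amine nitrogen is a methoxy-bearing phenyl ring, so it remains open how a plain phenyl, a chlorophenyl or a pyridine ring would read at that place. Going by these compounds, it is equally open whether a carboxylic acid or a dimethylamino group on that ring, or a longer alkoxy chain in place of methoxy, would give a step that reaches beyond the scatter.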